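This account rests on a few compounds, and the source may have more. Where it says the series, first, only, none or still open, it means among the compounds named here.

Compound 1 `CC(CCCCC(=O)NO)Nc1c(Nc2ccccc2)c(=O)c1=O` and compound 2 `CC(CCCCC(=O)NO)Nc1c(Nc2ccc(C(F)(F)F)cc2)c(=O)c1=O` share one core and differ only by a trifluoromethyl in place of hydrogen on an aromatic carbon. In an ADME assay on cells (Hepatocyte, Homo sapiens) for pharmacokinetics, read by LC-MS, with a stated time of 90 min, tested at 1 uM (a higher number here means faster removal of the compound, a lower number slower removal), compound 1 gives < 5 uL/min, which is a limit of the assay rather than a number (the limit of < 5 uL/min in this assay, at which 1 of the 2 values shown sits). In this assay, among the measured compounds shown here, compound 2 gives 21 uL/min, the only number obtained so far. The step of an at least 4.2-fold higher number from compound 1 to compound 2 (0.62 log units; beyond the scatter) is thus read against a limit. Compound 3 `CC(C)C(CCCCC(=O)NO)Nc1c(Nc2ccc(C(F)(F)F)cc2)c(=O)c1=O` is not yet measured; it differs from compound 2 by isopropyl in place of methyl on a saturated chain carbon bound to a nitrogen on an aromatic ring and a saturated chain carbon. For the measured compounds named here, the one measured step concerns an aromatic carbon, not this saturated chain carbon, so no measured step bears on the change and no direction can be taken from the data. With nothing to point either way, the step of a 1.2-fold higher number from compound 2 to compound 3 (0.08 log units; within the scatter) is expected to fall within the scatter. The estimate for compound 3 in this assay is 25 uL/min, with a range from 10 uL/min to 60 uL/min.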

Compound 3, intrinsic clearance in a liver preparation (reported as CLH), per the amount of preparation that the assay uses in the Hepatocyte assay: 27 uL/min
Compound 3: the middle estimate sits 1.1-fold (0.03 log units) below what was measured, and the stated range covers the measured number.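

Among the compounds shown here, in the Hepatocyte assay, the first change at this saturated chain carbon gives a 1.3-fold higher number from compound 2 to compound 3 (0.11 log units; within the scatter), so isopropyl in place of methyl leaves this read-out unmoved beyond the scatter. In a physicochemical assay for solubility, with a stated time of 24 h, tested at 30 mg/mL (on this read-out lower numbers stand for lower solubility and higher numbers for higher solubility), compound 2 gives 20000000 nM and compound 3 gives 6300000 nM. The same change therefore separates the two read-outs, with solubility lower and clearance within the scatter: the measured solubility of compound 2, 20000000 nM, and of compound 3, 6300000 nM, a 3.2-fold lower number (0.50 log units; beyond the scatter)

Open, going by these compounds, is whether an amine or a hydroxymethyl group at this saturated chain carbon would leave the number in the Hepatocyte assay within the scatter of compound 2 while keeping solubility at the level of compound 2. Also open is how isopropyl behaves at this carbon without trifluoromethyl on the aromatic carbon, since the compounds shown pair it only with that group.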